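A few compounds are considered here, and "the series" means these few. Any claim that something is new, unique, unknown or untested is made for them only; others in the source may bear on it.

In a functional assay on Jurkat cells (Homo sapiens) for antiproliferative activity, read by MTT assay, with a stated time of 72 h (a higher number here means a weaker inhibitor, a lower number a stronger inhibitor), compound 3 (`COc1ccc(-c2c(C(=O)c3cc(OC)c(OC)c(OC)c3)sc3ccccc23)c(OC)c1`) gives 4000 nM, within the scatter of compound 1 (`COc1cc(C(=O)c2sc3ccccc3c2-c2ccc(F)cc2)cc(OC)c1OC`) at 2300 nM and of compound 2 (`COc1ccccc1-c1c(C(=O)c2cc(OC)c(OC)c(OC)c2)sc2ccccc12`) at 2900 nM. Compound 4 (`COc1ccc(-c2c(C(=O)c3cc(OC)c(OC)c(OC)c3)sc3ccccc23)cc1C`) carries 4-methoxy-3-methylphenyl in place of 2,4-dimethoxyphenyl on an aromatic carbon. Three measured steps at this aryl group bear on the change: a 1.3-fold higher number from compound 1 to compound 2 (0.10 log units; within the scatter), a 1.7-fold higher number from compound 1 to compound 3 (0.24 log units; within the scatter) and a 1.4-fold higher number from compound 2 to compound 3 (0.14 log units; within the scatter). All three lie within the scatter, so no step beyond the scatter is expected in this assay. Going by the values given here, no measured compound has a methyl group on this ring, so the range stays wide. The estimated step is a 1.4-fold lower number from compound 3 to compound 4 (0.15 log units; within the scatter). For compound 4 the expected value is 2800 nM, with an estimated range of 800 nM to 6000 nM.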

Compound 4, half-maximal inhibitory concentration: > 10000 nM
Compound 4: no number, only a limit; the forecaster's own chance of this, stated with the estimate: 3%; middle value at least 3.5-fold (0.55 log units) from the limit.
By their numbers in this assay, from the lowest: compounds 1, 2 and 3 (each within the scatter of the next). At a limit, above all of these: compound 4.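

Compound 4 has no number, only a limit: the limit of > 10000 nM in this assay, at which 1 of the 4 values shown sits. The steps of an at least 2.5-fold higher number from compound 3 to compound 4 (0.39 log units; beyond the scatter) and an at least 3.4-fold higher number from compound 2 to compound 4 (0.53 log units; beyond the scatter) and an at least 4.3-fold higher number from compound 1 to compound 4 (0.63 log units; beyond the scatter) all lie beyond the scatter. This aryl position is therefore not indifferent to its group, although 4-fluorophenyl, 2-methoxyphenyl and 2,4-dimethoxyphenyl stayed within the scatter of one another.

Whether the methyl group alone accounts for the change stays open, since only compound 4 carries one on this ring. As far as these compounds go, how an amine or a carboxylic acid on this ring would fare also remains unknown.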